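Adding a large amide chain to compound 1

The source may report more compounds than this note shows. Statements on the series, on what has been measured and on what is new or still open speak of the compounds shown alone.

Values so far in a physicochemical assay for lipophilicity, read by HPLC, at pH 7.5 (a lower number here means a more polar compound, a higher number a more lipophilic compound), for the measured compounds

compound 1 `CCOc1ccccc1-c1ccc(-c2nc3cnccc3cc2C#N)cc1` gives 3.8
compound 2 `CCOc1ccccc1-c1ccc(-c2nc3cncc(Cl)c3c(N[C@H](CC)C(N)=O)c2C#N)cc1` gives 3.7
compound 3 `CC[C@@H](Nc1c(C#N)c(-c2ccc(Br)cc2)nc2cnccc12)C(=O)O` gives 1.6

Compound 1 stands at the upper end of these three numbers. Going by the values given here, it lies within the scatter of compound 2 and well beyond the scatter from compound 3, the one clearly lower value.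

The next compound to be read is compound 4 `CCCCC(Nc1c(C#N)c(-c2ccc(-c3ccccc3OCC)cc2)nc2cnccc12)C(N)=O`, which differs from compound 1 in one place (a group of 9 heavy atoms (6 carbon, 2 nitrogen, 1 oxygen; no ring) in place of a hydrogen atom, on an aromatic carbon). A group without a ring replaces a hydrogen atom on an aromatic carbon, ortho to a cyano group and opposite the ring nitrogen.

Among the compounds with values here, no step between two measured compounds isolates a change of this kind, so any expectation rests on indirect evidence. Compound 2 (3.7) also carries an amide-ending chain on its core, and its number stays within the scatter of compound 1 (3.8). Compound 3 (1.6) ends in an acid instead, and compound 4 has no such group. A small step upward or none beyond the scatter is therefore expected in this assay for this change. The estimated step is a number 0.10 log units higher from compound 1 to compound 4 (within the scatter) and it is expected to stay within the scatter. The estimate for compound 4 is 3.9 with an expected range from 3.4 to 4.4 in the coming measurement.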

Compound 4, distribution coefficient: 3.6
Beside the measured number, compound 4's estimate is 0.30 log units above it, and the stated range covers the measured number.
By their numbers in this assay, from the lowest: compound 3; then compounds 4, 2 and 1 (each within the scatter of the next).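

Going by these compounds alone, on the aromatic carbon ortho to a cyano group and opposite the ring nitrogen, a group of 9 heavy atoms (6 carbon, 2 nitrogen, 1 oxygen; no ring) in place of a hydrogen atom gives, in this assay, a number 0.20 log units lower from compound 1 to compound 4 (within the scatter) and is the only step here that isolates a change at this position. It shows that a group of this size, with 2 hydrogen-bond donors and 2 hydrogen-bond acceptors, can stand on this carbon of the core of compound 1 while the distribution coefficient stays within the usual scatter of the measurement. Nothing in the data given accounts for this outcome, so it stands as an observation on a single pair of compounds.

A single step cannot tell whether this result is particular to this group or holds for other groups on the same carbon. From the compounds shown here alone, it remains open how the reading in this assay would respond if an amine, a morpholine ring or a longer chain stood on this carbon in place of the hydrogen atom of compound 1, with the rest of the structure unchanged.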